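Adding a methoxy to a benzyl group: what to expect

A few compounds are considered here, and "the series" means these few. Any claim that something is new, unique, unknown or untested is made for them only; others in the source may bear on it.

Measured so far in a physicochemical assay for solubility, with a stated time of 3 days, at pH 7; on this read-out lower numbers stand for lower solubility and higher numbers for higher solubility
- Compound 1 `NC(=O)c1ccc2[nH]c(-c3ccc(OCC4CCCNC4)cc3)nc2c1` gives "not determined" (no result reported)
- Compound 2 `Cc1ccc(CN2CCC(COc3ccc(-c4nc5cc(C(N)=O)ccc5[nH]4)cc3)CC2)cc1` gives "not determined" (no result reported)
- Compound 3 `NC(=O)c1ccc2[nH]c(-c3ccc(OCCC4CCCCN4Cc4ccccc4)cc3)nc2c1` gives 155000 nM

Among the compounds with values here, compound 3 holds the only number here, since compound 1 and compound 2 have no reported result. Within the data shown here, it therefore cannot be ranked against any neighbour, and no measured pair shows how far a small structural change moves this read-out.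

The next compound to be measured is compound 4 `COc1ccc(CN2CCCCC2CCOc2ccc(-c3nc4cc(C(N)=O)ccc4[nH]3)cc2)cc1` and it differs from compound 3 in one place (methoxy in place of hydrogen on an aromatic carbon). A methoxy stands in place of a hydrogen on an aromatic carbon, para to a large group, so that benzyl becomes 4-methoxybenzyl. The rest of the molecule stays the same.

Among the measured compounds shown here, with no measured step to serve as a guide, the expectation in this assay is a small move downward, possibly no larger than the usual scatter of repeated measurements. For the measured compounds named here, the only anchor is compound 3 at 155000 nM and the uncertainty around any forecast from a single value is wide. The estimated change is a 1.3-fold lower number from compound 3 to compound 4 (0.11 log units; within the scatter) and it could turn out to be no real change at all. In this assay compound 4 is estimated at 120000 nM (expected range from 55000 nM to 230000 nM).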

Compound 4, solubility: 84000 nM
Estimate against measurement, compound 4: 1.4-fold (0.15 log units) above, within the range that was stated.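

In this assay, the swap of hydrogen for methoxy on this benzyl group gives a 1.8-fold lower number from compound 3 to compound 4 (0.27 log units; within the scatter), so the two compounds cannot be told apart on this read-out. This gives the first view of the position: methoxy, placed on an aromatic carbon para to a large group, is a change that leaves the number inside the normal spread of repeat measurements, and a real but small shift cannot be separated from chance. With a single pair, this holds only for this one swap on this one molecule and makes no trend, and nothing on hand gives a reason for the number.

Still open, as far as these compounds go, is whether a different group in the same place, such as a carboxylic acid, an amine or a longer chain like ethoxy, would move the number beyond that spread. From the compounds shown here alone, it is also open whether the same methoxy swap would give a similar step on a molecule whose chain and saturated ring differ from those of compound 3.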